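The source may hold more compounds than are shown below. What is called first, only, known or untested is meant among the compounds shown, and "the series" means these compounds.

Three measured compounds and one still to be measured are described here. Compound 1 `Nc1nc(Cl)c2ncn(Cc3ccc(CCl)cc3)c2n1`, compound 2 `ClCc1cccc(Cn2cnc3c(Cl)nc(Cl)nc32)c1` and compound 3 `ClCc1ccc(Cn2cnc3c(Cl)nc(Cl)nc32)cc1` have been tested, and compound 4 `Nc1nc(Cl)c2ncn(Cc3cccc(CCl)c3)c2n1` has not. All four were studied in a functional assay on NCI-H23 cells (Homo sapiens) for cytotoxicity, read by sulforhodamine B assay, with a stated time of 48 h; on this read-out higher numbers stand for weaker inhibition of growth and lower numbers for stronger inhibition of growth. In this assay compound 1 gives 12000 nM, compound 2 gives 2130 nM and compound 3 gives 7590 nM, so compound 2 shows the lowest number of the three.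

Compound 3 and compound 1 differ in one place: amino in place of chloro on an aromatic carbon. That change produced a 1.6-fold higher number from compound 3 to compound 1 (0.20 log units; within the scatter). Compound 2 and compound 3 are built from the same atoms joined differently; the difference between the two cores is not broken down here.

Compound 4 relates to compound 2 exactly as compound 1 relates to compound 3: amino in place of chloro on an aromatic carbon. The surroundings of the change are the same in both pairs, so this is the same change. If it behaves as before, the step from compound 2 to compound 4 is expected to be a 1.6-fold higher number from compound 2 to compound 4 (0.20 log units; within the scatter), because the matching change gave a 1.6-fold higher number from compound 3 to compound 1 (0.20 log units; within the scatter). On that basis compound 4 is estimated to give 3400 nM in this assay, with the likely range running from 1500 nM to 8000 nM.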

Compound 4, concentration for 50% growth inhibition: 2040 nM
The estimate for compound 4 lay 1.7-fold (0.22 log units) above the measured number; low and high end bracket the measured number.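

In this assay, placing amino instead of chloro on the aromatic carbon between two ring nitrogen atoms gave a 1.0-fold lower number from compound 2 to compound 4 (0.02 log units; within the scatter), so on this core the swap leaves the number essentially unchanged. Set beside the earlier pair, the change carries over from one core to the other without a detectable difference: the same change on two cores in this assay, a 1.6-fold higher number (0.20 log units; within the scatter) from compound 3 to compound 1 and a 1.0-fold lower number (0.02 log units; within the scatter) from compound 2 to compound 4, 1.7-fold (0.22 log units) apart, within the scatter of two such steps. This supports treating the swap as having little visible effect on growth inhibition across these two pairs, but it does not show that the swap has no effect at all, since a small shift could hide within the scatter, and two pairs in a single cell line cannot establish a rule for other cores, cells or read-outs, nor explain why the two steps agree.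

The compounds shown leave open whether a different group on that same aromatic carbon, such as a methylamino or methoxy group, would also leave the number unchanged or would move it beyond the scatter. They also leave open how far the number depends on the chloromethyl group, which could be tested by replacing it with a hydroxymethyl or a plain methyl group.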